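An Isopropoxy Exchange Among Closely Matched Values

The source may hold more compounds than are shown below. What is called first, only, known or untested is meant among the compounds shown, and "the series" means these compounds.

In a functional assay on DLD-1 cells (Homo sapiens) for cytotoxicity, with a stated time of 48 h (a lower number here means a stronger inhibitor, a higher number a weaker inhibitor), compound 1 `Cc1cccc2c(=O)cc(/C=C/[S+](C)[O-])oc12` gives 6800 nM, compound 2 `CCCCOc1ccc2oc(/C=C/[S+](C)[O-])cc(=O)c2c1` gives 4800 nM and compound 3 `C[S+]([O-])/C=C/c1cc(=O)c2cc(F)ccc2o1` gives 7000 nM, which places compound 3 within the scatter of both others. The unmeasured compound 4 `CC(C)Oc1ccc2oc(/C=C/[S+](C)[O-])cc(=O)c2c1` differs from compound 3 by isopropoxy in place of fluoro on an aromatic carbon. Going by the values given here, one measured step bears on this exchange: a 1.5-fold higher number from compound 2 to compound 3 (0.16 log units; within the scatter), for fluoro in place of butoxy on an aromatic carbon. It runs in the opposite direction and involves a different alkoxy group, so no step beyond the scatter is expected in this assay. The estimated step is a 1.3-fold lower number from compound 3 to compound 4 (0.10 log units; within the scatter). Compound 4 is estimated at 5500 nM, within a range of 3000 nM to 10000 nM.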

Compound 4, half-maximal inhibitory concentration: 8000 nM
For compound 4 the middle estimate is 1.5-fold (0.16 log units) below the measured one, within the range that was stated.
By their numbers in this assay, from the lowest: compounds 2, 1, 3 and 4 (each within the scatter of the next).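

In this assay, isopropoxy in place of fluoro gives a 1.1-fold higher number from compound 3 to compound 4 (0.06 log units; within the scatter), so at this aromatic carbon the exchange of a single fluorine for the larger alkoxy group produces no step beyond the scatter. Within the alkoxy groups, isopropyl in place of butyl on the oxygen gives a 1.7-fold higher number from compound 2 to compound 4 (0.22 log units; within the scatter), which also stays within the scatter. The compounds shown leave open whether an amine, a carboxylic acid or a chain longer than butoxy on this carbon would give a step beyond the scatter. No evidence on the reason for these small steps is at hand.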